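This account rests on a few compounds, and the source may have more. Where it says the series, first, only, none or still open, it means among the compounds named here.

In a functional assay on A2780 cells (Homo sapiens) for antiproliferative activity, read by MTT assay, with a stated time of 72 h (a lower number here means a stronger inhibitor, a higher number a weaker inhibitor), three compounds sharing one core have been measured. Compound 1 `CC(C)CNC(=N)NC(=N)Nc1ccc(F)c(F)c1` gives 6700 nM, compound 2 `CC(C)NC(=N)NC(=N)Nc1ccc(F)c(F)c1` gives 26000 nM and compound 3 `CCN(CC)C(=N)NC(=N)Nc1ccc(F)c(F)c1` gives 20400 nM. Compound 2 has the highest number only nominally: the nearest step, a 1.3-fold lower number from compound 2 to compound 3 (0.11 log units; within the scatter), does not separate the two values, whereas the furthest, a 3.9-fold higher number from compound 1 to compound 2 (0.59 log units; beyond the scatter), is a modest one. Compound 4 `CCCCCCCNC(=N)NC(=N)Nc1ccc(F)c(F)c1` has not yet been measured. It differs from compound 2 by heptyl in place of isopropyl on an amine nitrogen, with heptyl in place of isopropyl on an amine nitrogen. The most relevant evidence is the change at this same nitrogen between isobutyl and isopropyl, a 3.9-fold higher number from compound 1 to compound 2 (0.59 log units; beyond the scatter), where compound 1, with isobutyl, has the lower number. Among the compounds with values here, no measured compound carries a heptyl, so this is a cautious extrapolation from a single step. A lower number of modest to moderate size is expected, an estimated 6.5-fold lower number from compound 2 to compound 4 (0.81 log units; beyond the scatter). Compound 4 is estimated at 4000 nM, with an expected range from 1200 nM to 13000 nM.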

Compound 4, half-maximal inhibitory concentration: 1500 nM
Compound 4: middle estimate off by 2.7-fold (0.43 log units), on the high side, within the range that was stated.
By their numbers in this assay, from the lowest: compound 4; then compound 1; then compounds 3 and 2 (each within the scatter of the next).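

In this assay, within the data shown here, the heptyl chain on this amine nitrogen carries the number well past anything the earlier compounds reached, with a large step (a 17-fold lower number from compound 2 to compound 4 (1.24 log units; beyond the scatter)) and a further modest one beyond the isobutyl compound (a 4.5-fold lower number from compound 1 to compound 4 (0.65 log units; beyond the scatter)). Among compounds 2, 1 and 4, each with a single alkyl group on this nitrogen, the number thus falls as the group grows from isopropyl through isobutyl to heptyl, so the earlier isobutyl gain was not the limit at this position; compound 3, with diethylamino, does not fit this single-chain series and stays within the scatter of compound 2. Nothing available explains why the longer chain gives the lower number.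

The compounds shown leave open whether a longer chain such as nonyl or dodecyl would lower the number further or reverse the trend. They also leave open whether chain length or the absence of branching matters more, which an unbranched butyl or a cyclohexyl group on the same nitrogen would help to separate.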